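The source may hold more compounds than are shown below. What is called first, only, known or untested is meant among the compounds shown, and "the series" means these compounds.

Measured in a functional assay on NSCLC cells (Homo sapiens) for cytotoxicity, read by sulforhodamine B assay, with a stated time of 48 h; a higher number here means a weaker inhibitor of growth, a lower number a stronger inhibitor of growth:
compound 1 `COc1cc2c(cc1C)NC(=O)/C2=C/c1c(OC)nc2sc(C)cn12`: 74900 nM
compound 2 `COc1ccc2c(c1)/C(=C\c1c(OC)nc3sc(C)cn13)C(=O)N2`: 58700 nM
compound 3 `COc1nc2sc(C)cn2c1/C=C1/C(=O)Nc2ccc(O)cc21`: 72000 nM

All three values lie close together, and compound 3 stands within the scatter of both other compounds. Compound 4 `COc1nc2sc(C)cn2c1/C=C1/C(=O)Nc2ccccc21` differs from compound 3 by hydrogen in place of hydroxy on an aromatic carbon. Among the measured compounds shown here, two measured steps bear on this change: a 1.3-fold lower number from compound 1 to compound 2 (0.11 log units; within the scatter), hydrogen in place of methyl on an aromatic carbon, and a 1.2-fold higher number from compound 2 to compound 3 (0.09 log units; within the scatter), hydrogen in place of methyl on an oxygen on an aromatic ring. Neither is the same change, and both stay within the scatter. No shift beyond the scatter is therefore expected in this assay. The expected step is a 1.1-fold lower number from compound 3 to compound 4 (0.04 log units; within the scatter). Compound 4 is estimated at 66000 nM, with an expected range from 35000 nM to 110000 nM.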

Compound 4, concentration for total growth inhibition: 65200 nM
The estimate for compound 4 lay 1.0-fold (0.01 log units) above the measured number; measured number inside the range.
By their numbers in this assay, from the lowest: compounds 2, 4, 3 and 1 (each within the scatter of the next).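

In this assay, hydrogen in place of hydroxy on this aromatic carbon gives a 1.1-fold lower number from compound 3 to compound 4 (0.04 log units; within the scatter), and hydrogen in place of methoxy gives a 1.1-fold higher number from compound 2 to compound 4 (0.05 log units; within the scatter), both within the scatter. The earlier compounds shown here all carried an oxygen group here, whereas compound 4 shows that the number stays within the scatter with no such group at this position. No evidence is available to explain this result.

Every step shown at this position stays within the scatter, so it remains open whether an amine or a carboxylic acid here would shift the number beyond it.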